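A few compounds are considered here, and "the series" means these few. Any claim that something is new, unique, unknown or untested is made for them only; others in the source may bear on it.

For the measured compounds named here, in an assay on IMR-32 cells for displacement of a labelled ligand from corticotropin-releasing factor receptor 1 (Homo sapiens), read by scintillation counting, with a stated time of 2 h (on this read-out higher numbers stand for weaker inhibition and lower numbers for stronger inhibition), compound 2 `CCc1nc(-c2ccc(Cl)cc2Cl)c(CC)nc1NC(CC)CC` gives 4.1 nM, the lowest of the three numbers measured so far. Compound 1 `CCC(CC)Nc1nc(OC)c(-c2ccc(Cl)cc2Cl)nc1C` gives 14.4 nM, and compound 3 `CCc1nc(NC(CC)CC)c(F)nc1-c1ccc(Cl)cc1Cl` gives 167 nM. Going by the values given here, the only measured step between two compounds that differ in a single place is a 41-fold higher number from compound 2 to compound 3 (1.61 log units; beyond the scatter), a change at a different position of the shared core. Compound 4 `CCc1nc(-c2ccc(Cl)cc2Cl)c(CC)nc1SC(C)CC` differs from compound 2 as follows: (sec-butyl)sulfanyl in place of (pentan-3-yl)amino on an aromatic carbon. Among the compounds with values here, no measured step bears on a swap of (pentan-3-yl)amino for (sec-butyl)sulfanyl, so the size of the step is uncertain, and a moderate weakening is expected, a 9.8-fold higher number from compound 2 to compound 4 (0.99 log units; beyond the scatter). Compound 4 is therefore estimated at 40 nM, with a range from 8 nM to 200 nM.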

Compound 4, inhibition constant: 401 nM
Compound 4: the middle estimate sits 10-fold (1.00 log units) below what was measured, outside the stated range (above it).
By their numbers in this assay, from the lowest: compound 2; then compound 1; then compound 3; then compound 4.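

For the compounds shown here, this is the first measured change at this position, next to the ring nitrogen, and in this assay (sec-butyl)sulfanyl in place of (pentan-3-yl)amino gives a 98-fold higher number from compound 2 to compound 4 (1.99 log units; beyond the scatter) on the shared core. So this position is sensitive to the swap, which changes several things at once: the entering group has 5 heavy atoms rather than 6, sulfur replaces nitrogen, and it has 0 hydrogen-bond donors rather than 1. No measurement shown accounts for the step. The compounds shown leave open whether the linking atom or the chain matters more. A (sec-butyl)amino group or a (pentan-3-yl)sulfanyl group would separate the two.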